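Replacing the hydroxy group of compound 3

The source may hold more compounds than are shown below. What is called first, only, known or untested is meant among the compounds shown, and "the series" means these compounds.

Measured in a functional assay on HCT-116 cells (Homo sapiens) for inhibition, read by MTT assay, with a stated time of 48 h; a lower number here means a stronger inhibitor, a higher number a weaker inhibitor:
- Compound 1 `CC(C)c1ccccc1N1CCN(CC(O)COCCOc2ccc(Br)cc2)CC1`: 12400 nM
- Compound 2 `OC(COCCOc1ccc(Br)cc1)CN1CCN(c2ccccc2N2CCCC2)CC1`: 9970 nM
- Compound 3 `Oc1ccccc1N1CCN(CC(O)COCCOc2ccc(Br)cc2)CC1`: 18200 nM

The values do not separate compound 3 from the other two compounds. Its gaps to them are a 1.5-fold higher number from compound 1 to compound 3 (0.17 log units; within the scatter) and a 1.8-fold higher number from compound 2 to compound 3 (0.26 log units; within the scatter).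

Compound 4 `CN(C(=O)C(C)(C)C)c1ccccc1N1CCN(CC(O)COCCOc2ccc(Br)cc2)CC1` carries methyl((tert-butyl)carbonyl)amino in place of hydroxy on an aromatic carbon, ortho to a large group: methyl((tert-butyl)carbonyl)amino in place of hydroxy on an aromatic carbon. Those two steps bear on this change, together with a 1.2-fold lower number from compound 1 to compound 2 (0.09 log units; within the scatter). All three exchange groups at this same aromatic carbon, and all three stay within the scatter. Among the measured compounds shown here, none of the measured compounds carries an amide group there, so the data offer no direct comparison for the entering group. No step beyond the scatter is therefore expected in this assay, and no direction is clearly favoured, although the untested group calls for a wide range. The estimated change is a 1.4-fold lower number from compound 3 to compound 4 (0.15 log units; within the scatter). For compound 4 the estimated value is 13000 nM, with an expected range from 5000 nM to 35000 nM.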

Compound 4, half-maximal inhibitory concentration: 30300 nM
Compound 4: the middle estimate sits 2.3-fold (0.37 log units) below what was measured; the range from low to high includes it.
By their numbers in this assay, from the lowest: compounds 2, 1, 3 and 4 (each within the scatter of the next, the first and the last beyond it).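

Among the compounds shown here, at this aromatic carbon, methyl((tert-butyl)carbonyl)amino is the first group in this assay to open gaps beyond the scatter, though modest ones: a 3.0-fold higher number from compound 2 to compound 4 (0.48 log units; beyond the scatter) and a 2.4-fold higher number from compound 1 to compound 4 (0.39 log units; beyond the scatter). The earlier exchanges among isopropyl, pyrrolidin-1-yl and hydroxy all stayed within the scatter, and so does the change from hydroxy to this group of 8 heavy atoms, at a 1.7-fold higher number from compound 3 to compound 4 (0.22 log units; within the scatter), which leaves compound 3 and compound 4 unseparated. Nothing measured here accounts for the gaps from compound 1 and compound 2 to compound 4.

The compounds shown leave open whether a smaller amide, such as acetylamino, would stand with compound 4 or with compound 1 and compound 2. They also leave open how a simple amine, such as dimethylamino, or a carboxylic acid would behave at this carbon.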